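The source may hold more compounds than are shown below. What is called first, only, known or untested is meant among the compounds shown, and "the series" means these compounds.

Measured compounds:
- compound 1 `Cc1c(O)cc(CCCCC(C)[C@H](C)O)oc1=O` — > 200000 nM, a limit
- compound 2 `COc1cc(CCCCC(C)(C)O)oc(=O)c1C` — > 200000 nM, a limit

Compound 2 `COc1cc(CCCCC(C)(C)O)oc(=O)c1C` stands on the shared core with a methoxy on the aromatic ring and a tertiary alcohol at the end of the chain. In a functional assay on BGC-823 cells (Homo sapiens) for cytotoxicity, read by MTT assay (on this read-out lower numbers stand for stronger inhibition and higher numbers for weaker inhibition), compound 2 gives only a limit, > 200000 nM. Compound 1, which carries a hydroxy on the ring and a secondary alcohol on the chain, likewise gives only a limit in this assay, > 200000 nM. Going by the values given here, both values shown therefore sit at the same limit, (the limit of > 200000 nM in this assay, at which 2 of the 2 values shown sit), and no step between measured compounds can be sized.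

The next compound, compound 3 `Cc1c(O)cc(CCCCC(C)(C)O)oc1=O`, differs from compound 2 at one place: hydrogen in place of methyl on an oxygen on an aromatic ring. Compound 1 already pairs a hydroxy on the ring with a chain alcohol and reaches no number in this assay, so the change is expected to shift nothing beyond the scatter, and the step from compound 2 to compound 3 is estimated as a step that the limit leaves unreadable from compound 2 to compound 3. Compound 3 is expected to give 250000 nM, most likely again as a limit, within a range of 60000 nM to 1000000 nM.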

Compound 3, half-maximal inhibitory concentration: > 200000 nM
Compound 3 gave a limit, no number; the forecaster's own chance of this, stated with the estimate: 80%; the middle value does not contradict the limit.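

Neither step among compound 1, compound 2 and compound 3 can be read, since all three stand only as limits: the limit of > 200000 nM in this assay, at which 3 of the 3 values shown sit.

The compounds shown leave open whether any change to the ring oxygen or the chain on the shared core would give an actual number in this assay.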